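Lipophilicity notes on a chloropyrimidine isomer pair

The source may hold more compounds than are shown below. What is called first, only, known or untested is meant among the compounds shown, and "the series" means these compounds.

Measured compounds:
compound 1: `Clc1ccc2c(NCCCNc3ccnc(N4CCCCC4)n3)ccnc2c1` — 0.801
compound 2: `Clc1ccc2c(NCCCNc3nccc(Cl)n3)ccnc2c1` — 0.657

In a physicochemical assay for lipophilicity, read by HPLC, in phosphate buffer, measured as octanol-water partition, with a stated time of 24 h, at pH 7.4 (a higher number here means a more lipophilic compound, a lower number a more polar compound), compound 1 gives 0.801 and compound 2 gives 0.657. Compound 2 stands as the lower of the two numbers shown, and its nearest neighbour is compound 1, a number higher by an amount that stays within the scatter, so the two readings cannot be told apart. Within the data shown here, no step between measured compounds that differ in a single place is available.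

Compound 3 `Clc1ccc2c(NCCCNc3ccnc(Cl)n3)ccnc2c1` has not yet been measured in this assay. It differs from compound 2 in one place: 2-chloropyrimidin-4-yl in place of 4-chloropyrimidin-2-yl on an amine nitrogen The two structures hold the same atoms joined differently, so nothing is added or removed, only the point at which the ring is attached is moved. No measured pair in the series tests such a rearrangement, so there is no shown step to lean on. The expectation is a step of a number 0.09 log units higher from compound 2 to compound 3 (within the scatter), judged to be small and not beyond the scatter in either direction. For compound 3 the estimate in this assay is 0.75, with a range from 0.35 to 1.15.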

Compound 3, distribution coefficient: 0.229
The estimate for compound 3 lay 0.52 log units above the measured number; measured number below the stated range.
By their numbers in this assay, from the lowest: compound 3; then compounds 2 and 1 (each within the scatter of the next).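

In this assay, moving the point of attachment on an amine nitrogen is not a neutral rearrangement: 2-chloropyrimidin-4-yl in place of 4-chloropyrimidin-2-yl gives a number 0.43 log units lower from compound 2 to compound 3 (beyond the scatter), although the two groups have the same heavy atoms and the same counts of hydrogen-bond donors and acceptors. With the 2-chloropyrimidin-4-yl attachment held fixed, the series also gains its first step for a change of group on an aromatic carbon, with chloro in place of piperidin-1-yl corresponding to a number 0.57 log units lower from compound 1 to compound 3 (beyond the scatter). No measurement at hand accounts for either step.

Still open, as far as these compounds go, is whether the difference between the two attachments persists when chloro is replaced by another group, such as methoxy or a dimethylamino group, on the pyrimidine ring. Also open, from the compounds shown here alone, is whether a longer chain between the two amine nitrogens would preserve the size of the step seen between the attachments or change it.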